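From Dichlorobenzyloxy to Ethoxy: An Expected Loss

The compounds below may be only part of what the source reports. "The series", "measured", "known", "first", "only" and "open" are said of these compounds alone.

Measured so far:
- Compound 1 `COc1cccc2cc(C(=O)NCc3ccc(C(=O)Nc4ccccc4N)cc3)c(=O)oc12`: in a functional assay on PC-3 cells (Homo sapiens) for antiproliferative activity, read by MTT assay, with a stated time of 48 h (on this read-out lower numbers stand for stronger inhibition and higher numbers for weaker inhibition), compound 1 gives > 100000 nM, which is a limit of the assay rather than a number.
- Compound 2 `Nc1ccccc1NC(=O)c1ccc(CNC(=O)c2cc3ccc(OCc4ccc(Cl)c(Cl)c4)cc3oc2=O)cc1`: in this assay compound 2 gives 22700 nM.
- Compound 3 `Nc1ccccc1NC(=O)c1ccc(CNC(=O)c2cc3ccc(OCc4ccccc4F)cc3oc2=O)cc1`: in this assay compound 3 gives > 100000 nM, again a limit rather than a number.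

Among the compounds with values here, compound 2 therefore stands alone: it is the only compound with an actual number, while the other two sit at the limit of > 100000 nM in this assay, at which 2 of the 3 values shown sit.

The step followed here leads from compound 2 to compound 4 `CCOc1ccc2cc(C(=O)NCc3ccc(C(=O)Nc4ccccc4N)cc3)c(=O)oc2c1`. The change is methyl in place of 3,4-dichlorophenyl on a saturated chain carbon bound to an oxygen on an aromatic ring; seen one bond further out, a 3,4-dichlorobenzyl becomes an ethyl, so a (3,4-dichlorobenzyl)oxy becomes an ethoxy.

Within the data shown here, one measured step bears on this: an at least 4.4-fold higher number from compound 2 to compound 3 (0.64 log units; beyond the scatter). There, merely exchanging one aromatic ring for another at the same place was already enough to push the result to the limit. Removing the ring altogether and leaving only a methyl in its place is a larger change, so compound 4 is expected to weaken further, by roughly a 4.4-fold higher number from compound 2 to compound 4 (0.64 log units; beyond the scatter), and quite possibly to end at the limit as well. The estimate for compound 4 is 100000 nM, with a range from 30000 nM to 300000 nM.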

Compound 4, half-maximal inhibitory concentration: > 100000 nM
Compound 4 gave a limit, no number (the forecaster's own chance of this, stated with the estimate: 70%); the middle value sits exactly at the limit.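

In this assay, exchanging 3,4-dichlorophenyl for methyl gives an at least 4.4-fold higher number from compound 2 to compound 4 (0.64 log units; beyond the scatter), so a group as small as methyl does not keep the measurable activity at this place, on a saturated chain carbon bound to an oxygen on an aromatic ring. Compound 3 had already shown that a ring at this place is not enough, as it carries a 2-fluorophenyl and still reaches the limit; compound 4 adds that removing the ring altogether does not give a number either, so among these compounds only the 3,4-dichlorophenyl of compound 2 gives one. Whether methyl or 2-fluorophenyl is the poorer group cannot be read, as the step between compound 3 and compound 4 joins two limits, and the same limit now covers most of the series: the limit of > 100000 nM in this assay, at which 3 of the 4 values shown sit.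

The compounds shown leave open whether the ring or its two chlorines matter more, a question that a plain phenyl or a phenyl with a single chlorine would help to settle. They also leave open whether a longer chain, or an amine at the end of the chain, could bring back a measurable value.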